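Trifluoromethyl for Chloro on a Shared Urea Core

This account rests on a few compounds, and the source may have more. Where it says the series, first, only, none or still open, it means among the compounds named here.

Of the compounds shown here, three built on one shared core have been measured in an assay on isolated protein for inhibition of transient receptor potential cation channel subfamily V member 1 (Homo sapiens), read by calcium flux; a higher number here means a weaker inhibitor, a lower number a stronger inhibitor. Compound 1 `O=C(Nc1cccc2[nH]ncc12)NC1CCc2ncccc21` gives 5820 nM. Compound 2 `CC(C)(C)c1cccc2c1CCC2NC(=O)Nc1cccc2[nH]ncc12` gives 14 nM. Compound 3 `O=C(Nc1cccc2[nH]ncc12)NC1CCc2cc(Cl)ccc21` gives 10 nM, the lowest of the three numbers; its gap to compound 2 lies within the scatter, whereas compound 1 lies far beyond it. Compound 4 `O=C(Nc1cccc2[nH]ncc12)NC1CCc2cc(C(F)(F)F)ccc21` has not yet been measured. It differs from compound 3 in one place: trifluoromethyl in place of chloro on an aromatic carbon. Among the compounds with values here, no step between measured compounds matches this change. The step of a 1.2-fold higher number from compound 3 to compound 4 (0.08 log units; within the scatter) is expected to be small, in no clear direction, and within the usual scatter. Compound 4 is therefore estimated to give 12 nM, in a range from 4 nM to 40 nM.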

Compound 4, half-maximal inhibitory concentration: 3 nM
The estimate for compound 4 lay 4.0-fold (0.60 log units) above the measured number; measured number outside the range, below it.
By their numbers in this assay, from the lowest: compound 4; then compounds 3 and 2 (each within the scatter of the next); then compound 1.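

In this assay, this aromatic carbon proves sensitive to the choice of group: trifluoromethyl in place of chloro gives a modest step beyond the scatter (a 3.3-fold lower number from compound 3 to compound 4 (0.52 log units; beyond the scatter)), the first single-place step available among these compounds. Chloro is therefore not the best group possible at this position. No measurement shown here explains the gain.

The compounds shown leave open how a nitrile, a methoxy group or a bromine would fare on this same carbon. They also leave open whether trifluoromethyl would give a similar step elsewhere on this ring.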